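The source may hold more compounds than are shown below. What is called first, only, known or untested is meant among the compounds shown, and "the series" means these compounds.

Measured compounds:
Compound 1, `CCC(Sc1nc(Cl)cc(Nc2nc(-c3ccc(Cl)cc3)cs2)n1)C(=O)O`: 3600 nM in an assay for inhibition of Polyunsaturated fatty acid 5-lipoxygenase (Homo sapiens), read by HPLC, with stated times of 15 min and 10 min; on this read-out lower numbers stand for stronger inhibition and higher numbers for weaker inhibition
Compound 2, `O=C(O)CSc1nc(Cl)cc(Nc2nc(-c3ccc(Cl)cc3)cs2)n1`: > 10000 nM in this assay, a limit of the assay rather than a number

Compound 2 therefore stands at the weak end of the two measured compounds, known only as a limit (the limit of > 10000 nM in this assay, at which 1 of the 2 values shown sits). Compound 3, `O=C(O)C(Sc1nc(Cl)cc(Nc2nc(-c3ccc(Cl)cc3)cs2)n1)c1cccc2ccccc12`, has not yet been measured; it differs from compound 2 by naphthalen-1-yl in place of hydrogen on a saturated chain carbon bound to a carbonyl carbon and a sulfur. Among the measured compounds shown here, the one measured step that bears on this position is an at least 2.7-fold higher number from compound 1 to compound 2 (0.44 log units; beyond the scatter), where taking ethyl away from this chain carbon weakened inhibition. Putting a group back onto the same carbon is expected to move the number the other way, and the larger naphthalen-1-yl is expected to do at least what ethyl did in compound 1 with 3600 nM. The step of an at least 5.0-fold lower number from compound 2 to compound 3 (0.69 log units; beyond the scatter) is thus the expected gain. Compound 3 is estimated at 2000 nM, within 400 nM to 10000 nM.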

Compound 3, half-maximal inhibitory concentration: 400 nM
Estimate against measurement, compound 3: 5.0-fold (0.70 log units) above; low and high end bracket the measured number.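

In this assay, naphthalen-1-yl in place of hydrogen on the saturated chain carbon bound to a carbonyl carbon and a sulfur gives an at least 25-fold lower number from compound 2 to compound 3 (1.39 log units; beyond the scatter). The position therefore does not stop at what ethyl gave: with naphthalen-1-yl in place of ethyl on the same carbon there is a 9.0-fold lower number from compound 1 to compound 3 (0.95 log units; beyond the scatter), so this carbon carries a group of 10 heavy atoms and inhibition still gains. The first of these steps is open-ended, because compound 2 is known only as a limit: the limit of > 10000 nM in this assay, at which 1 of the 3 values shown sits.

From the compounds shown here alone, it remains open whether phenyl, naphthalen-2-yl or a longer chain such as butyl on this carbon would go as far as naphthalen-1-yl. Also open, going by these compounds, is what an amide in place of the carboxylic acid would do to this gain.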